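Amide carbonyl substituent in a histamine receptor series

The source may report more compounds than this note shows. Statements on the series, on what has been measured and on what is new or still open speak of the compounds shown alone.

Going by the values given here, compound 2 `CC1CCCN1C1CCN(c2ccc(NC(=O)CC3CCCC3)cc2)C1` gives 3.1 nM in an assay on CHO cells for displacement of a labelled ligand from histamine receptor H3 (Macaca mulatta) (on this read-out lower numbers stand for stronger inhibition and higher numbers for weaker inhibition), the lowest of the two numbers measured so far. Compound 1 `Cc1cc(N2CCC(N3CCCC3C)C2)ccc1NC(=O)C1CC1` gives 9.6 nM in this assay, a gap from compound 2 that lies beyond the usual scatter. Compound 3 `CC1CCCN1C1CCN(c2ccc(NC(=O)C3CC3)cc2)C1` is not yet measured. Its change from compound 2 is cyclopropyl in place of cyclopentylmethyl on a carbonyl carbon. Among the compounds with values here, no single-point step between measured compounds is known, so the expectation rests on the two values alone. A modest weakening is expected in this assay, a 1.9-fold higher number from compound 2 to compound 3 (0.29 log units; within the scatter). Compound 3 is estimated at 6 nM in this assay, with a range from 2.5 nM to 15 nM.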

Compound 3, inhibition constant: 9.7 nM
The estimate for compound 3 lay 1.6-fold (0.21 log units) below the measured number; the range from low to high includes it.
By their numbers in this assay, from the lowest: compound 2; then compounds 1 and 3 (each within the scatter of the next).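

In this assay, going by these compounds alone, the group on this carbonyl carbon matters: cyclopropyl in place of cyclopentylmethyl gives a 3.1-fold higher number from compound 2 to compound 3 (0.50 log units; beyond the scatter) and this is the first single-place change to show it. With cyclopropyl held fixed, hydrogen in place of methyl on an aromatic carbon gives a 1.0-fold higher number from compound 1 to compound 3 (0.00 log units; within the scatter) and so that methyl shows no effect here. No measurement at hand explains the change on the carbonyl carbon.

Still open, on these data alone, is whether ring size or the methylene link carries the step, which cyclopentyl or cyclopropylmethyl would separate. An amine or a longer chain on this carbon also remains untested in the compounds shown.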